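The source may report more compounds than this note shows. Statements on the series, on what has been measured and on what is new or still open speak of the compounds shown alone.

Measured so far in an ADME assay on Karpas-1106P cells (Homo sapiens) for cytotoxicity; a lower number here means that less compound is needed, a higher number that more compound is needed for the effect:
compound 1 `Cc1ccc(S(=O)(=O)N[C@@H](CC(=O)NC(C)(C)C)C(=O)NCCNC(=O)c2ccccc2Cl)cc1`: > 11100 nM
compound 2 `Cc1ccc(S(=O)(=O)N[C@@H](CC(=O)NC(C)(C)C)C(=O)NCCNC(=O)c2ccc(F)cc2)cc1`: > 11100 nM
compound 3 `Cc1ccc(S(=O)(=O)N[C@@H](CC(=O)NC(C)(C)C)C(=O)NCCNC(=O)c2ccc(Cl)cc2)cc1`: > 11100 nM

Among the measured compounds shown here, all three entries are limits of the assay and not numbers, and the series so far is summed up by the limit of > 11100 nM in this assay, at which 3 of the 3 values shown sit. Compound 3 has no number of its own, only the limit > 11100 nM. It therefore cannot be ranked against compound 1 or compound 2.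

The next compound, compound 4 `Cc1ccc(S(=O)(=O)N[C@@H](CC(=O)NC(C)(C)C)C(=O)NCCNC(=O)c2ccc(F)c(F)c2)cc1`, differs from compound 3 in one place: 3,4-difluorophenyl in place of 4-chlorophenyl on a carbonyl carbon. There, 3,4-difluorophenyl takes the place of 4-chlorophenyl on a carbonyl carbon.

For the measured compounds named here, three measured steps concern this same place. The closest is a step that the two limits leave unreadable from compound 2 to compound 3, since it also exchanges fluoro and chloro. The other two are a step that the two limits leave unreadable from compound 1 to compound 2 and a step that the two limits leave unreadable from compound 1 to compound 3. None of them gives a size, so none can be carried over, and no direction can be read from them. In this assay, then, no step beyond the scatter is expected, and compound 4 will most likely also be reported only as a limit. The expected change is a step that the limit leaves unreadable from compound 3 to compound 4. For compound 4 the estimate is 12000 nM, with an expected range from 6000 nM to 30000 nM.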

Compound 4, half-maximal effective concentration: > 11100 nM
Compound 4 gave a limit, no number (the forecaster's own chance of this, stated with the estimate: 85%); the middle value does not contradict the limit.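

Compound 4 is reported at > 11100 nM, which is a limit of this assay and not a number. Among the compounds shown here, no step from compound 1, compound 2 or compound 3 to compound 4 can be read, and the series stays at one limit: the limit of > 11100 nM in this assay, at which 4 of the 4 values shown sit. The compounds shown leave open whether any group on this carbonyl carbon would give a readable value in this assay.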